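The compounds below may be only part of what the source reports. "The series", "measured", "known", "first", "only" and "open" are said of these compounds alone.

Measured compounds:
compound 1 `COc1ccc(-c2cc(-c3ccc(S(=O)(=O)NC4CC4)cc3)cnc2N)cn1` gives 1.9 h in an in vitro ADME assay on microsomes from liver (Homo sapiens) for metabolic stability; on this read-out lower numbers stand for a shorter-lived compound and higher numbers for a longer-lived compound
compound 2 `COc1ccc(-c2cc(-c3ccc4cnn(C)c4c3)cnc2N)cn1` gives 2.38 h in this assay

Of the two numbers in this assay, compound 1 holds the lowest; its nearest neighbour is compound 2, whose number is higher by an amount that stays within the scatter, so the two cannot be told apart. Compound 3 `COc1ccc(-c2cc(-c3ccc(C(N)=O)cc3)cnc2N)cn1` has not yet been measured in this assay. It differs from compound 1 in one place: carbamoyl in place of cyclopropylsulfamoyl on an aromatic carbon. Among the compounds with values here, no pair of measured compounds shows this change, so no step can be read off from the data. Within the data shown here, with only two measured compounds that sit within the scatter of each other, the step from compound 1 to compound 3 is expected to be small, in either direction or none beyond the scatter, as a 1.2-fold higher number from compound 1 to compound 3 (0.06 log units; within the scatter). Compound 3 is therefore estimated at 2.2 h, within a range from 1.1 h to 4.4 h.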

Compound 3, half-life: > 4.16 h
Compound 3 gave a limit, no number (the forecaster's own chance of this, stated with the estimate: 5%); middle value at least 1.8-fold (0.27 log units) away from the limit.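

Within the data shown here, at this place, on an aromatic carbon para to a large group, the earlier compounds showed no change at all, and the swap of cyclopropylsulfamoyl for carbamoyl now gives a step beyond the scatter in this assay, an at least 2.1-fold higher number from compound 1 to compound 3 (0.34 log units; beyond the scatter). Compound 3 gives > 4.16 h, which is a limit of the assay and not a number. The step therefore has a floor but no measured size: the limit of > 4.16 h in this assay, at which 1 of the 3 values shown sits.

The compounds shown leave open which part of the change carries the step, since the three-membered ring and the sulfur leave together, and a plain sulfamoyl group would separate the two. Also open, from the compounds shown here alone, is whether a nitrile or a carboxylic acid at this place would give a number like that of carbamoyl.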